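Compound 2 Drawn Without Configurations: Compound 4

The source may hold more compounds than are shown below. What is called first, only, known or untested is meant among the compounds shown, and "the series" means these compounds.

Compound 2, `CC(C)(C)OC(=O)N1C[C@@H]2CC[C@@H]1C[C@@H]2Oc1ncnc(Nc2ccc(S(C)(=O)=O)cc2F)c1[N+](=O)[O-]`, was tested in a functional assay on HEK293 cells for agonist activity at Glucose-dependent insulinotropic receptor (Homo sapiens), read by TR-FRET and cAMP accumulation, with a stated time of 60 min (on this read-out lower numbers stand for an effect already at smaller amounts and higher numbers for an effect only at larger amounts of compound), and gave 1.2 nM, the lowest of the two numbers available here. Compound 1, `CC(C)(C)OC(=O)N1CC2CC(Oc3ncnc(Nc4ccc(S(C)(=O)=O)cc4)c3[N+](=O)[O-])C1C2`, gives 315 nM in this assay, a gap beyond the usual scatter. Compound 3, `CC(C)(C)OC(=O)N1CC2CCC1CC2Oc1ncnc(Nc2ccc(S(C)(=O)=O)cc2)c1[N+](=O)[O-]`, was measured more than once in this assay, and its entries read 3.1 nM; > 10000 nM (2 entries). Two of these entries of compound 3 are a limit of the assay and not a number.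

Compound 4, `CC(C)(C)OC(=O)N1CC2CCC1CC2Oc1ncnc(Nc2ccc(S(C)(=O)=O)cc2F)c1[N+](=O)[O-]`, keeps every atom and bond of compound 2; the only difference is in the drawing: the two compounds have the same atoms and bonds; at least one stereo element is drawn with a configuration in one of them and without one in the other: 3 of 3 stereo elements differ; a stereocentre at a saturated ring carbon is drawn S in compound 2 and without a configuration in compound 4; a stereocentre at a saturated ring carbon is drawn R in compound 2 and without a configuration in compound 4; a stereocentre at a saturated ring carbon is drawn S in compound 2 and without a configuration in compound 4. Among the measured compounds shown here, no step between two measured compounds of this kind exists in the set, so the direction for this assay has to be judged from compound 2 alone, and no change beyond the scatter is expected if the material behind compound 4 matches that of compound 2. Because the several entries of compound 3 in this assay, 3.1 nM; > 10000 nM (2 entries) shows that a compound drawn without configurations returned both a number and a limit in the same assay, a wide range and a real chance of a limit are expected for compound 4. Compound 4 is estimated at 4 nM, between 1 nM and 40 nM. This estimate means an expected step of a 3.3-fold higher number from compound 2 to compound 4 (0.52 log units; beyond the scatter).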

Compound 4, half-maximal effective concentration: > 10000 nM
Compound 4 gave a limit, no number; the forecaster's own chance of this, stated with the estimate: 40%; middle value at least 2500-fold (3.39 log units) from the limit.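

In this assay the result gives an at least 8300-fold higher number from compound 2 to compound 4 (3.92 log units; beyond the scatter), although nothing separates the two compounds except how their three ring stereocentres are drawn: the fact that one of compounds 2 and 4 is drawn with a defined configuration and the other without, at the place where they differ. Compound 4 reads > 10000 nM, which is a limit of the assay and not a number. The earlier compounds had shown this limit only in repeated entries for a single compound, beside a number for that same compound, whereas here a limit and a low number are attached to the same atoms and bonds, one drawn with configurations and one without, so the drawing at these ring carbons can no longer be treated as a detail of notation: the several entries of compound 3 in this assay, 3.1 nM; > 10000 nM (2 entries).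

The compounds shown do not tell which configurations the material behind compound 4 actually holds, nor whether any single stereoisomer other than compound 2 gives a number in this assay. As far as these compounds go, it also stays open whether so wide a gap between the defined and the undefined drawing would persist with a nitrile in place of the nitro group on the shared core.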